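Compound 3 to compound 4: one side group changes

The source may hold more compounds than are shown below. What is called first, only, known or untested is meant among the compounds shown, and "the series" means these compounds.

Measured in an ADME assay on HEK293 cells (Homo sapiens) for cytotoxicity, read by ATP content, with a stated time of 6 h; a lower number here means that less compound is tolerated, a higher number that more compound is tolerated:
Compound 1 `CCCCNc1nc(N)nc2ccn(Cc3ncc(C)c(OC)c3C)c12`: > 24000 nM (a limit)
Compound 2 `CCCCNc1nc(N)nc2ccn(Cc3ncccc3OC)c12`: > 24000 nM (a limit)
Compound 3 `COCCCNc1nc(N)nc2ccn(Cc3ccccn3)c12`: > 24000 nM (a limit)

None of these entries is an exact number. Compound 3 stands where the other two stand, at the limit of > 24000 nM in this assay, at which 3 of the 3 values shown sit. Its neighbour in this story, compound 4 `Cc1cnc(CNc2nc(N)nc3ccn(Cc4ccccn4)c23)o1`, has not yet been measured. The change is in one place: 5-methyl-1,3-oxazol-2-yl in place of 2-methoxyethyl on a saturated chain carbon bound to a nitrogen on an aromatic ring. In words, 5-methyl-1,3-oxazol-2-yl comes in place of 2-methoxyethyl on a saturated chain carbon bound to a nitrogen on an aromatic ring.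

Among the measured compounds shown here, no measured pair shows what a single change does in this assay, so the expectation rests on the values alone. Compound 3 reads > 24000 nM, which is a limit. Expected here is a step that the limit leaves unreadable from compound 3 to compound 4, meaning no step beyond the scatter and no clear direction. For compound 4 the estimate is 30000 nM, with an expected range from 15000 nM to 60000 nM.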

Compound 4, half-maximal cytotoxic concentration: > 24000 nM
Compound 4: a limit, no number; the forecaster's own chance of this, stated with the estimate: 85%; the middle value lies beyond the limit too.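

No step can be read from compound 3 to compound 4 in this assay, because both entries are limits rather than numbers: the limit of > 24000 nM in this assay, at which 4 of the 4 values shown sit.

The compounds shown leave open the concentration at which any of them would reach half-maximal cytotoxicity, and whether 5-methyl-1,3-oxazol-2-yl in place of 2-methoxyethyl alters it.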